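Swapping the aryl group on the ring nitrogen of compound 1

This account rests on a few compounds, and the source may have more. Where it says the series, first, only, none or still open, it means among the compounds named here.

Measured compounds:
compound 1 `Nc1scc(CN2CCN(c3cccc(Cl)c3Cl)CC2)c1C(=O)c1ccc(Cl)cc1`, -57%
compound 2 `COc1ccc(N2CCN(Cc3csc(N)c3C(=O)c3ccc(Cl)cc3)CC2)cc1`, -15%
compound 3 `Nc1scc(CN2CCN(c3ccc([N+](=O)[O-])cc3)CC2)c1C(=O)c1ccc(Cl)cc1`, -8.3%

In a functional assay on CHO cells with adenosine receptor A1 (Homo sapiens) as the target, read by cAMP accumulation and immunoassay, with a stated time of 6 min, tested at 1 uM (a higher number here means a weaker effect of the compound at the concentration tested, a lower number a stronger effect), compound 1 gives the lowest of the three numbers. Its nearest neighbour is compound 2, reached by a number 42 percentage points higher from compound 1 to compound 2 (beyond the scatter); furthest is compound 3, reached by a number 48.7 percentage points higher from compound 1 to compound 3 (beyond the scatter). Between compound 2 and compound 3 the step is a number 6.7 percentage points higher from compound 2 to compound 3 (within the scatter).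

Compound 4 `Nc1scc(CN2CCN(c3ccc(F)cc3F)CC2)c1C(=O)c1ccc(Cl)cc1` has not yet been measured in this assay. It differs from compound 1 in one place: 2,4-difluorophenyl in place of 2,3-dichlorophenyl on an amine nitrogen in a ring.

Both measured steps that bear on this position, a number 42 percentage points higher from compound 1 to compound 2 (beyond the scatter) and a number 48.7 percentage points higher from compound 1 to compound 3 (beyond the scatter), are large, and both replace the 2,3-dichlorophenyl with a different group on the amine nitrogen in the ring. Neither involves 2,4-difluorophenyl, so the evidence is indirect. An upward step beyond the scatter, smaller than those two, is therefore expected. The expected step is a number 27 percentage points higher from compound 1 to compound 4 (beyond the scatter). For compound 4 the estimate in this assay is -30%, with a range from -58% to -5%.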

Compound 4, a percentage reported as activity, at one concentration (the size of the read-out at that concentration, not a potency): -66%
Estimate against measurement, compound 4: 36 percentage points above; the measured number lies below the stated range.
By their numbers in this assay, from the lowest: compounds 4 and 1 (each within the scatter of the next); then compounds 2 and 3 (each within the scatter of the next).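

Replacing 2,3-dichlorophenyl with 2,4-difluorophenyl on the amine nitrogen in the ring does not separate the two compounds, with a number 9 percentage points lower from compound 1 to compound 4 (within the scatter), so the strong effect in this assay is not confined to the 2,3-dichlorophenyl group. The same 2,4-difluorophenyl group stands well apart from the other two aryl groups, with a number 57.7 percentage points lower from compound 3 to compound 4 (beyond the scatter) and a number 51 percentage points lower from compound 2 to compound 4 (beyond the scatter), so among these four compounds the two aryl groups carrying two halogens group together, and the 4-nitrophenyl and 4-methoxyphenyl compounds group together. No measurement is available that explains this split.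

The compounds shown leave open whether two halogens are needed at all. A plain phenyl, a 4-fluorophenyl or a 4-chlorophenyl group could fall with either pair, and the same holds for a 2,4-dichlorophenyl group.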